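Adding a Second Methoxy Group to Compound 2

The source may report more compounds than this note shows. Statements on the series, on what has been measured and on what is new or still open speak of the compounds shown alone.

The compounds measured so far:
compound 1, `CC(Oc1ccc(Cl)cc1Cl)C(=O)NCc1ccc(Cl)cc1`, 39000 nM
compound 2, `COc1ccc(CNC(=O)C(C)Oc2ccc(Cl)cc2Cl)cc1`, 71000 nM
compound 3, `COc1ccc(CNC(=O)C(C)Oc2ccc(Cl)cc2Cl)cc1OC`, 36000 nM

All three were tested in an ADME assay on CHO cells (Cricetulus griseus) for cytotoxicity, read by LDH release; a higher number here means a weaker inhibitor, a lower number a stronger inhibitor. Among these numbers compound 2 stands highest, though the step of a 1.8-fold higher number from compound 1 to compound 2 (0.26 log units; within the scatter) and the step of a 2.0-fold lower number from compound 2 to compound 3 (0.29 log units; within the scatter) both lie within the scatter, so no order among the three can be claimed.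

The unmeasured compound 4, `COc1ccc(CNC(=O)C(C)Oc2ccc(Cl)cc2Cl)c(OC)c1`, differs from compound 2 in one place: methoxy in place of hydrogen on an aromatic carbon. The new methoxy sits ortho to a large group and meta to a methoxy group, so the change is the same in kind as the step from compound 2 to compound 3, only at a different aromatic carbon. Going by the values given here, that earlier step, a 2.0-fold lower number from compound 2 to compound 3 (0.29 log units; within the scatter), stayed within the scatter, and it is the only measured step that bears directly on the present one. A step of similar size, or none beyond the scatter, is therefore expected in this assay for compound 4, with a 1.4-fold lower number from compound 2 to compound 4 (0.15 log units; within the scatter) as the expected step. Compound 4 is estimated at 50000 nM, within a range from 20000 nM to 120000 nM.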

Compound 4, half-maximal inhibitory concentration: > 100000 nM
Compound 4: no number, only a limit (the forecaster's own chance of this, stated with the estimate: 15%); middle value at least 2.0-fold (0.30 log units) from the limit.
By their numbers in this assay, from the lowest: compounds 3, 1 and 2 (each within the scatter of the next). At a limit, above all of these: compound 4.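

In this assay, compound 4 is the first of the compounds shown to carry a methoxy group on this aromatic carbon, ortho to a large group and meta to a methoxy group, and it gives no number, only a limit of the assay: the limit of > 100000 nM in this assay, at which 1 of the 4 values shown sits. The step reads an at least 1.4-fold higher number from compound 2 to compound 4 (0.14 log units; that floor lies within the scatter); this is a floor alone, and it neither establishes a change beyond the scatter nor rules one out. The same replacement of hydrogen by methoxy at a different aromatic carbon gave a 2.0-fold lower number from compound 2 to compound 3 (0.29 log units; within the scatter), a step with a definite size, whereas the step at this carbon has none, so the two cannot be ranked against each other.

Going by these compounds, how far the true value of compound 4 lies past the limit remains open, and with it the real size of this step. Also open, on these data alone, is what a hydroxyl group, an amine or a carboxylic acid on this same aromatic carbon would give in this assay, and whether any such group would yield a number rather than a limit.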